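The compounds below may be only part of what the source reports. "The series", "measured", "known", "first", "only" and "open" are said of these compounds alone.

Compound 1, `COc1cc2c(Oc3ccc(NC(=O)c4cn(-c5ccccc5OC)cn4)cc3F)ccnc2cc1OCCCN1CCN(C)CC1`, gives 220 nM in a functional assay on MKN-45 cells (Homo sapiens) for cytotoxicity, read by MTT assay, with a stated time of 72 h; a higher number here means a weaker inhibitor, a lower number a stronger inhibitor.
Compound 2, `COc1cc2c(Oc3ccc(NC(=O)c4cn(-c5ccccc5OC)cn4)cc3F)ccnc2cc1OCCCN1CCCCC1`, gives 260 nM.
Compound 3, `COc1cc2c(Oc3ccc(NC(=O)/C=C/S(=O)(=O)c4ccccc4OC)cc3F)ccnc2cc1OCCCN1CCN(C)CC1`, gives 430 nM.

Compound 4, `COc1cc2c(Oc3ccc(NC(=O)/C=C/S(=O)(=O)c4ccccc4OC)cc3F)ccnc2cc1OCCCN1CCCCC1`, has not yet been measured. Compound 2 differs from compound 1 by piperidin-1-yl in place of 4-methylpiperazin-1-yl on a saturated chain carbon, three bonds along the chain from an oxygen on an aromatic ring, and that change produced a 1.2-fold higher number from compound 1 to compound 2 (0.07 log units; within the scatter). The same change, (piperidin-1-yl in place of 4-methylpiperazin-1-yl on a saturated chain carbon, three bonds along the chain from an oxygen on an aromatic ring), separates compound 4 from compound 3; the difference between the cores of compound 1 and compound 3 is not broken down here. Compound 3 lies within the usual scatter of both compound 1 and compound 2, so no ordering among the three measured compounds can be claimed. Among the measured compounds shown here, compound 4 is expected to show a similar small step, a 1.2-fold higher number from compound 3 to compound 4 (0.07 log units; within the scatter), because the only precedent for this change is a 1.2-fold higher number from compound 1 to compound 2 (0.07 log units; within the scatter). Compound 4 is therefore estimated at 500 nM, most likely between 250 nM and 1000 nM.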

Compound 4, half-maximal inhibitory concentration: 980 nM
Estimate against measurement, compound 4: 2.0-fold (0.29 log units) below; low and high end bracket the measured number.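

In this assay, piperidin-1-yl in place of 4-methylpiperazin-1-yl gives a 2.3-fold higher number from compound 3 to compound 4 (0.36 log units; beyond the scatter). Set beside the earlier step on the other core, this step does not differ from it by more than repeated measurements allow: the same change on two cores in this assay, a 1.2-fold higher number (0.07 log units; within the scatter) from compound 1 to compound 2 and a 2.3-fold higher number (0.36 log units; beyond the scatter) from compound 3 to compound 4, 1.9-fold (0.29 log units) apart, within the scatter of two such steps. The change therefore carries from one core to the other without a demonstrable difference, but two pairs cannot show that its size is truly the same on both cores, and they do not establish that it depends on the core.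

The compounds shown leave open how other amines at the chain end, such as morpholin-4-yl or dimethylamino, would compare on either core. They also leave open whether the step would hold with a longer chain or on a third core.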